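The source may hold more compounds than are shown below. What is called first, only, known or untested is meant among the compounds shown, and "the series" means these compounds.

In a functional assay on the whole organism with Mus musculus as the target (on this read-out higher numbers stand for an effect only at larger amounts of compound and lower numbers for an effect already at smaller amounts), compound 1 (`Cc1cc2c(c(C)c1N)CC(C)(C)O2`) gives 16.3 mg/kg and compound 2 (`Cc1c(C)c2c(c(C)c1N)CC(C)(CSc1ccccc1)O2`) gives 24.7 mg/kg on the same read-out. Compound 3 (`Cc1c(C)c2c(c(C)c1N)CC(C)(CSc1ccc(F)cc1)O2`) gives 17.9 mg/kg and so lies within the usual scatter of both other compounds, which means these three numbers cannot be ranked. The next compound to consider, compound 4 (`Cc1c(C)c2c(c(C)c1N)CC(C)(CSc1ccncc1)O2`), differs from compound 3 in one place: pyridin-4-yl stands in place of 4-fluorophenyl on a sulfur (pyridin-4-yl in place of 4-fluorophenyl on a sulfur). Among the measured compounds shown here, only one measured step comes close to this change. It is a 1.4-fold lower number from compound 2 to compound 3 (0.14 log units; within the scatter) when fluoro replaces hydrogen on an aromatic carbon. For the measured compounds named here, that step alters a substituent, whereas compound 4 brings a ring with a hetero atom, and no measured compound shows what such a ring does. The evidence therefore gives no reason to expect a move beyond the scatter in this assay in either direction. The expected change is a 1.1-fold higher number from compound 3 to compound 4 (0.05 log units; within the scatter) and remains a cautious guess. For compound 4 the estimated dose is 20 mg/kg with an expected range from 9 mg/kg to 42 mg/kg around that estimate.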

Compound 4, dose for 50% inhibition: 19.9 mg/kg
Estimate against measurement, compound 4: 1.0-fold (0.00 log units) above, within the range that was stated.
By their numbers in this assay, from the lowest: compounds 1, 3, 4 and 2 (each within the scatter of the next).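

In this assay, swapping the fluorinated ring on the sulfur for pyridin-4-yl gives a 1.1-fold higher number from compound 3 to compound 4 (0.05 log units; within the scatter), and swapping the plain phenyl for the same group gives a 1.2-fold lower number from compound 2 to compound 4 (0.09 log units; within the scatter). Among the compounds shown here, this is the first look at a ring with a hetero atom at this place: a ring nitrogen, which adds a hydrogen-bond acceptor to the count, leaves the dose within the scatter of both carbon-only rings. No supporting measurement bears on this result.

For the compounds shown here, every step at this place so far stays within the scatter, so it remains open whether any group on this sulfur can move the dose beyond it. An amine, a carboxylic acid or a longer chain in place of the ring would test that, and the compounds shown say nothing about such groups.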